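A few compounds are considered here, and "the series" means these few. Any claim that something is new, unique, unknown or untested is made for them only; others in the source may bear on it.

Going by the values given here, compound 3 `CC(C)(C)c1ccc(CSc2ncnc3c2ncn3[C@@H]2O[C@H](CO)[C@@H](O)[C@H]2O)cc1` gives 10000 nM in an assay on isolated protein for inhibition of Equilibrative nucleoside transporter 1 (Homo sapiens) (a lower number here means a stronger inhibitor, a higher number a weaker inhibitor), the highest of the three numbers measured so far. Compound 1 `OC[C@H]1O[C@@H](n2cnc3c(SCc4ccccc4Cl)ncnc32)[C@H](O)[C@@H]1O` gives 117 nM in this assay, and compound 2 `OC[C@H]1O[C@@H](n2cnc3c(SCc4cccc(C(F)(F)F)c4)ncnc32)[C@H](O)[C@@H]1O` gives 19.1 nM. Compound 4 `OC[C@H]1O[C@@H](n2cnc3c(SCc4ccc(Cl)cc4Cl)ncnc32)[C@H](O)[C@@H]1O` differs from compound 3 by 2,4-dichlorophenyl in place of 4-(tert-butyl)phenyl on a saturated chain carbon bound to a sulfur. The measured steps that bear on this change are an 85-fold higher number from compound 1 to compound 3 (1.93 log units; beyond the scatter) and a 520-fold higher number from compound 2 to compound 3 (2.72 log units; beyond the scatter), both large. The ring entering compound 4 carries chlorine, as does that of compound 1, whose 117 nM lies far below the number of compound 3. A large downward step in this assay is therefore expected for compound 4, with a 67-fold lower number from compound 3 to compound 4 (1.82 log units; beyond the scatter). Compound 4 is estimated at 150 nM, with a range from 30 nM to 800 nM.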

Compound 4, inhibition constant: 4.37 nM
Estimate against measurement, compound 4: 34-fold (1.54 log units) above, outside the stated range (below it).
By their numbers in this assay, from the lowest: compound 4; then compound 2; then compound 1; then compound 3.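

Chloro in place of hydrogen on an aromatic carbon gives a 27-fold lower number from compound 1 to compound 4 (1.43 log units; beyond the scatter) in this assay and so shows that one added chlorine on this ring can move the number by a large step. With a 4.4-fold lower number from compound 2 to compound 4 (0.64 log units; beyond the scatter) and a 2300-fold lower number from compound 3 to compound 4 (3.36 log units; beyond the scatter) as well, compound 4 holds the lowest number of the four, and the groups on the saturated chain carbon bound to a sulfur now span a wider range. Nothing given here explains why these groups differ. The compounds shown leave open how an amine or a carboxylic acid on this ring would fare, and whether a longer chain in place of the saturated chain carbon would keep the low number of compound 4.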